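The compounds below may be only part of what the source reports. "The series", "measured", "known", "first", "only" and "open" are said of these compounds alone.

Of the compounds shown here, three of a shared core have been measured in a functional assay on DU-145 cells (Homo sapiens) for inhibition; on this read-out lower numbers stand for stronger inhibition and higher numbers for weaker inhibition. Compound 1 `Oc1ccc(-c2cc(-c3ccccc3F)cc(-c3ccc(O)cc3)n2)cc1` gives 7780 nM. For compound 3 `Oc1ccc(-c2cc(-c3cccc(C(F)(F)F)c3)cc(-c3ccc(O)cc3)n2)cc1` the assay reports only a limit, > 50000 nM. For compound 2 `Oc1ccc(-c2cc(-c3ccc(C(F)(F)F)cc3)cc(-c3ccccc3O)n2)cc1` likewise only a limit is reported, > 50000 nM. Compound 3 thus stands at the weak end of what the numbers show, sitting at the limit of > 50000 nM in this assay, at which 2 of the 3 values shown sit. For the measured compounds named here, the single step measured in one place, an at least 6.4-fold higher number from compound 1 to compound 3 (0.80 log units; beyond the scatter), moved the number beyond the scatter toward weaker inhibition.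

Compound 4 `Oc1ccc(-c2cc(-c3ccc(C(F)(F)F)cc3)cc(-c3ccc(O)cc3)n2)cc1` differs from compound 3 in one place: 4-(trifluoromethyl)phenyl in place of 3-(trifluoromethyl)phenyl on an aromatic carbon. Going by the values given here, no measured step bears directly on this exchange. Compound 2, which also carries the 4-(trifluoromethyl)phenyl group but differs from compound 4 in a second place, sits at the limit as well. Compound 3 shows only a limit in this assay, > 50000 nM, so the step estimated here, an at least 1.1-fold lower number from compound 3 to compound 4 (0.04 log units; that floor lies within the scatter), cannot be fixed against a number. Compound 4 is therefore expected to remain a weak inhibitor in this assay, with an estimate of 45000 nM, ranging from 10000 nM to 150000 nM, and a substantial chance that only a limit is reported again.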

Compound 4, half-maximal inhibitory concentration: > 50000 nM
Compound 4: no number, only a limit (the forecaster's own chance of this, stated with the estimate: 60%); middle value at least 1.1-fold (0.04 log units) away from the limit.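

In this assay compound 4 gives > 50000 nM, which is a limit and not a number, so the 4-(trifluoromethyl)phenyl group, opposite the ring nitrogen, does not lift the series off that limit. For the compounds shown here, the one new step that can be read, an at least 6.4-fold higher number from compound 1 to compound 4 (0.80 log units; beyond the scatter), places the 4-(trifluoromethyl)phenyl group with the 3-(trifluoromethyl)phenyl group of the earlier step, an at least 6.4-fold higher number from compound 1 to compound 3 (0.80 log units; beyond the scatter), as both go with weaker inhibition than the 2-fluorophenyl group at this position. The steps from compound 3 to compound 4 and from compound 2 to compound 4 cannot be read, so neither the shift of the trifluoromethyl group around the ring nor the exchange of 2-hydroxyphenyl for 4-hydroxyphenyl can be given a size, and the weak end now holds most of the compounds: the limit of > 50000 nM in this assay, at which 3 of the 4 values shown sit.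

Going by these compounds alone, compound 1 remains the only compound with a number, so it stays open how far this position tolerates other groups, such as an unsubstituted phenyl, a 4-fluorophenyl or a phenyl carrying an amine. Going by these compounds, it also stays open whether the exchange of 2-hydroxyphenyl for 4-hydroxyphenyl matters at all when the group at this position is 2-fluorophenyl.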